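Trifluoromethyl for trifluoromethoxy on two cores

The compounds below may be only part of what the source reports. "The series", "measured", "known", "first", "only" and "open" are said of these compounds alone.

Measured so far in an assay on isolated protein for inhibition of DNA topoisomerase 1 (Homo sapiens), with a stated time of 30 min, tested at 100 uM; on this read-out lower numbers stand for a weaker effect and higher numbers for a stronger effect at the one concentration tested:

compound 1 `CCN(CC)c1ccc2nc(-c3ccccc3OC(F)(F)F)[nH]c(=O)c2c1` gives 81.2%
compound 2 `CCN(CC)c1ccc2nc(-c3ccccc3C(F)(F)F)[nH]c(=O)c2c1` gives 81.7%
compound 3 `Cc1ccc2c(=O)[nH]c(-c3cccc(OC(F)(F)F)c3)nc2c1` gives 77.2%

Compound 1 and compound 2 share one core and differ in a single place: trifluoromethyl in place of trifluoromethoxy on an aromatic carbon. The step this change made in this assay is a number 0.5 percentage points higher from compound 1 to compound 2 (within the scatter), so the two values cannot be told apart on this read-out.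

Compound 3 sits on a second core. The difference between the two cores is not broken down here. The values of compound 1 and compound 3 in this assay lie within the scatter of each other, as do those of compound 2 and compound 3, so no order among the three measured compounds can be read from them.

Compound 4 `Cc1ccc2c(=O)[nH]c(-c3cccc(C(F)(F)F)c3)nc2c1` is not yet measured. It relates to compound 3 as compound 2 relates to compound 1: trifluoromethyl in place of trifluoromethoxy on an aromatic carbon. The surroundings of the place are not identical: in the pair of compound 1 and compound 2 the place is "ortho to a large group", whereas in the pair of compound 3 and compound 4 it is "meta to a large group". It is therefore the same kind of change, not the same change. Among the compounds shown it occurs two times in all, once measured and once pending.

The step from compound 3 to compound 4 in this assay is expected to be a number 0.8 percentage points higher from compound 3 to compound 4 (within the scatter), which is estimated to be small because a number 0.5 percentage points higher from compound 1 to compound 2 (within the scatter) stayed within the scatter. On that basis compound 4 is expected to give about 78% in this assay. The estimated range for compound 4 runs from 68% to 88%.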

Compound 4, a percentage reported as inhibition, at one concentration (the size of the read-out at that concentration, not a potency): 100%
Estimate against measurement, compound 4: 22 percentage points below; measured number outside the range, above it.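

In this assay, trifluoromethyl in place of trifluoromethoxy gives a number 22.8 percentage points higher from compound 3 to compound 4 (beyond the scatter), so the size of this step does not carry over from one core to the other in this series: the same change on two cores in this assay, a number 0.5 percentage points higher (within the scatter) from compound 1 to compound 2 and a number 22.8 percentage points higher (beyond the scatter) from compound 3 to compound 4, 22.3 percentage points apart, beyond the scatter of two such steps The pairs differ in more than the core, since the place is meta to a large group only in the pair of compound 3 and compound 4, so the data do not separate an influence of the core from an influence of the place. Among the compounds shown here, with only two pairs, read at a single concentration in this assay, the result shows that the step measured on one core was a poor guide to the step on the other, but it gives neither a cause nor a general rule, and it says nothing about potency.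

Still open, from the compounds shown here alone, is whether the larger step follows the core or the place, a question that trifluoromethyl and trifluoromethoxy meta to a large group on the core of compound 1 would bear on directly. Also open, going by these compounds, is how a nitrile, a carboxylic acid or a simple methoxy group at that place would read on either core in this assay.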